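Swapping a Phenol for a Toluene on an Anilino Group

This account rests on a few compounds, and the source may have more. Where it says the series, first, only, none or still open, it means among the compounds named here.

Measured so far:
compound 1, `COc1ccc(Nc2nc3ncccc3n2Cc2ccccc2)cc1`, 87300 nM
compound 2, `Cn1nc(-c2ccnc(Nc3ccc(O)cc3)n2)c2ccccc21`, 8430 nM

Both numbers come from a functional assay on HCT-116 cells (Homo sapiens) for antiproliferative activity, read by MTT assay, with a stated time of 72 h; a higher number here means a weaker inhibitor of growth, a lower number a stronger inhibitor of growth. Going by the values given here, compound 2 has the lowest number of the two; the only other compound, compound 1, sits higher, a gap beyond the usual scatter. Since the two share no single-point difference, nothing more can be read from that pair than what the two values show.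

Compound 3, `Cc1ccc(Nc2nccc(-c3nn(C)c4ccccc34)n2)cc1`, is the next compound and has not been measured. It differs from compound 2 in one place: methyl in place of hydroxy on an aromatic carbon. Among the compounds with values here, with no measured pair to lean on, the most defensible expectation is a modest step, if any, and the direction is open. The number for compound 3 in this assay is expected to be 12000 nM, with a range from 3000 nM to 50000 nM. That estimate corresponds to an expected step of a 1.4-fold higher number from compound 2 to compound 3 (0.15 log units; within the scatter).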

Compound 3, concentration for 50% growth inhibition: 8640 nM
Beside the measured number, compound 3's estimate is 1.4-fold (0.14 log units) above it, within the range that was stated.
By their numbers in this assay, from the lowest: compounds 2 and 3 (each within the scatter of the next); then compound 1.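

In this assay, going by these compounds alone, the swap of hydroxy for methyl gives a 1.0-fold higher number from compound 2 to compound 3 (0.01 log units; within the scatter) and provides the first single-point comparison here, one that leaves the two compounds indistinguishable. At this place, on an aromatic carbon para to a large group, the hydrogen-bond donor and acceptor counted for hydroxy can be lost with growth inhibition still reading alike in this pair. Nothing at hand explains why the two numbers agree.

Going by these compounds, whether an amine, a carboxylic acid or a longer chain such as ethyl at the same place would also read alike remains open. A single pair also cannot show whether the same swap would behave this way on a different core, or whether any group here could bring a number beyond the scatter of these two.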